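Imidazolyl in place of the guanidine on the core

The source may report more compounds than this note shows. Statements on the series, on what has been measured and on what is new or still open speak of the compounds shown alone.

Compound 1 `CC/N=C(\N)Nc1ccc(Sc2ccc(OC)cc2)cc1` gives 251 nM in an assay (Rattus norvegicus) for binding affinity to prostacyclin receptor (Homo sapiens), read by radioligand binding; a higher number here means a weaker inhibitor, a lower number a stronger inhibitor. Among the measured compounds shown here, of the three numbers so far it stands second highest: compound 2 `CS(=O)(=O)Nc1ccc(Sc2ccc(NC3=NCCN3)cc2)cc1` gives 79.4 nM in this assay, and compound 3 `COc1ccc(Sc2ccc(NC3=NCCCCN3)cc2)cc1` gives 1260 nM. Compound 2 differs from compound 1 in two places at once, so only its value is compared here.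

Compound 4 `COc1ccc(Sc2ccc(-c3ncc[nH]3)cc2)cc1` is the next entry. Relative to compound 1 the change is a group of 5 heavy atoms (3 carbon, 2 nitrogen; one five-membered aromatic ring with 2 hetero atoms) in place of a group of 6 heavy atoms (3 carbon, 3 nitrogen; no ring), on an aromatic carbon. For the measured compounds named here, no measured step matches this change. The only one that touches the same part of the core is a 5.0-fold higher number from compound 1 to compound 3 (0.70 log units; beyond the scatter), where the acyclic guanidine was closed into a seven-membered ring and the number rose. Compound 4 goes further: the guanidine is removed altogether, and the ring that enters is attached through carbon, not through a nitrogen. Compound 2 shows that a five-membered non-aromatic ring on the same nitrogen gives a low number, but it carries a second change, so it cannot be read as a step.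

Given that the only relevant measured change weakened binding, the expectation for compound 4 in this assay is a weaker number, with a step of about a 6.0-fold higher number from compound 1 to compound 4 (0.78 log units; beyond the scatter); the estimate is 1500 nM, within a range of 300 nM to 8000 nM.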

Compound 4, inhibition constant: < 10000 nM
Compound 4: no number, only a limit (the forecaster's own chance of this, stated with the estimate: 15%); the middle value lies beyond the limit too.
By their numbers in this assay, from the lowest: compound 2; then compound 1; then compound 3.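

In this assay, among the compounds shown here, compound 4 gives < 10000 nM as a limit and not a number, so no step from compound 1 to compound 4 can be read: the limit of < 10000 nM in this assay, at which 1 of the 4 values shown sits.

The compounds shown leave open whether 1H-imidazol-2-yl on the shared core, in place of the guanidine of compound 1, gives a higher or a lower number.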